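Dichlorophenyl variant of two growth-inactive sulfonamides

The source may hold more compounds than are shown below. What is called first, only, known or untested is meant among the compounds shown, and "the series" means these compounds.

Compound 1 `Cc1ccc(S(=O)(=O)NC2=NCCN2C(=S)SN2CCn3c2nsc3=S)cc1` gives >= 20000 nM in a functional assay on KYSE-510 cells (Homo sapiens) for antiproliferative activity, read by crystal violet staining, with a stated time of 96 h (on this read-out higher numbers stand for weaker inhibition of growth and lower numbers for stronger inhibition of growth), a limit of the assay.
Compound 2 `O=S(=O)(NC1=NCCN1C(=S)SN1CCn2c1nsc2=S)c1cccc(Cl)c1` gives >= 20000 nM in this assay, also a limit.

Compound 2 stands at the limit of >= 20000 nM in this assay, at which 2 of the 2 values shown sit, so no number is known for it. Compound 3 `O=S(=O)(NC1=NCCN1C(=S)SN1CCn2c1nsc2=S)c1ccc(Cl)cc1Cl` differs from compound 2 by 2,4-dichlorophenyl in place of 3-chlorophenyl on a sulfonyl sulfur. Among the compounds with values here, the only measured step, a step that the two limits leave unreadable from compound 1 to compound 2, is unreadable, with both ends at the limit, so it offers no guide to direction or size in this assay. Compound 3 is therefore expected to remain at or near the limit, with an estimate of 30000 nM (range 10000 nM to 100000 nM). This expectation corresponds to an estimated step that the limit leaves unreadable from compound 2 to compound 3.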

Compound 3, concentration for 50% growth inhibition: >= 20000 nM
Compound 3: no number, only a limit; the forecaster's own chance of this, stated with the estimate: 80%; the middle value lies beyond the limit too.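

Within the data shown here, compound 1, compound 2 and compound 3 all sit at a limit, so no step among them can be read. From the compounds shown here alone, whether changing the group on the sulfonyl sulfur affects growth inhibition in this assay stays open.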